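Replacing Trifluoromethyl with Nitro: Expected Antiproliferative Potency

A few compounds are considered here, and "the series" means these few. Any claim that something is new, unique, unknown or untested is made for them only; others in the source may bear on it.

Measured compounds:
Compound 1, `Cc1ccc(-c2csc(N3N=C(c4ccc(C)s4)CC3c3ccc(F)cc3)n2)cc1`, gives > 500 ug/mL in a functional assay on A549 cells (Homo sapiens) for antiproliferative activity, read by XTT assay, with a stated time of 24 h (on this read-out higher numbers stand for weaker inhibition and lower numbers for stronger inhibition), which is a limit of the assay and not a number.
Compound 2, `Cc1ccc(C2=NN(c3nc(-c4ccc(F)cc4)cs3)C(c3ccc(F)cc3)C2)s1`, gives 125 ug/mL in this assay.
Compound 3, `Fc1ccc(C2CC(c3ccc(Cl)s3)=NN2c2nc(-c3ccc(C(F)(F)F)cc3)cs2)cc1`, gives > 500 ug/mL in this assay, again a limit rather than a number.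

Compound 3 thus sits at the edge of what this assay can report; the limit of > 500 ug/mL in this assay, at which 2 of the 3 values shown sit, shows that two of the three values rest there, and only compound 2 yields a measured number. Within the data shown here, the only step with a measured size, an at least 4.0-fold lower number from compound 1 to compound 2 (0.60 log units; beyond the scatter), concerns fluoro in place of methyl and does not touch the groups changed here, so it offers little guidance. Compound 4, `O=[N+]([O-])c1ccc(-c2csc(N3N=C(c4ccc(Cl)s4)CC3c3ccc(F)cc3)n2)cc1`, differs from compound 3 by nitro in place of trifluoromethyl on an aromatic carbon. Among the measured compounds shown here, with compound 3 at a limit and no measured step bearing on this change, the expected step of an at least 1.2-fold lower number from compound 3 to compound 4 (0.09 log units; that floor lies within the scatter) is taken to lie within the scatter. Compound 4 is therefore estimated at 400 ug/mL, roughly between 150 ug/mL and 1000 ug/mL in this assay, with a fair chance that only a limit is reported again.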

Compound 4, half-maximal inhibitory concentration: > 500 ug/mL
Compound 4: a limit, no number (the forecaster's own chance of this, stated with the estimate: 55%); middle value at least 1.2-fold (0.09 log units) from the limit.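

No step can be read from compound 3 to compound 4, because both rest at a limit of the assay and not at a number: the limit of > 500 ug/mL in this assay, at which 3 of the 4 values shown sit.

As far as these compounds go, whether nitro or trifluoromethyl gives stronger inhibition stays open, as does how far either compound lies past that limit.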